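Aryl hydrazide series: a step from a limit

The source may hold more compounds than are shown below. What is called first, only, known or untested is meant among the compounds shown, and "the series" means these compounds.

Measured in a functional assay on MDA-MB-231 cells (Homo sapiens) for antiproliferative activity, read by MTT assay, with a stated time of 24 h; on this read-out lower numbers stand for stronger inhibition and higher numbers for weaker inhibition:
- compound 1 `Cc1cccc(NNC(=O)c2ccccc2NS(=O)(=O)c2cnc(O)nc2O)c1`: > 20000 nM
- compound 2 `O=C(NNc1ccccc1F)c1ccccc1NS(=O)(=O)c1cnc(O)nc1O`: > 20000 nM
- compound 3 `O=C(NNC(=O)c1ccccc1F)c1ccc(NS(=O)(=O)c2cnc(O)nc2O)cc1`: > 20000 nM

Each of these entries is a limit and not a number. Compound 2 has only its limit of > 20000 nM, and the other two readings are limits as well, so every reading sits at one point: the limit of > 20000 nM in this assay, at which 3 of the 3 values shown sit.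

Compound 4 `Cc1ccccc1C(=O)NNC(=O)c1ccccc1NS(=O)(=O)c1cnc(O)nc1O` has not yet been measured. Its difference from compound 2 is (2-methylphenyl)carbonyl in place of 2-fluorophenyl on an amine nitrogen. In words, (2-methylphenyl)carbonyl stands in place of 2-fluorophenyl on an amine nitrogen.

For the measured compounds named here, the only measured step, a step that the two limits leave unreadable from compound 1 to compound 2, offers no size to carry over. No direction can be taken from it, and no step beyond the scatter is expected in this assay. The expected change is a step that the limit leaves unreadable from compound 2 to compound 4, and it is most likely to remain unreadable. For compound 4 the estimate is 25000 nM, with an expected range of 10000 nM to 60000 nM, and a report as a limit is the likeliest outcome.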

Compound 4, half-maximal inhibitory concentration: 5570 nM
Beside the measured number, compound 4's estimate is 4.5-fold (0.65 log units) above it, outside the stated range (below it).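

In this assay, for the compounds shown here, (2-methylphenyl)carbonyl in place of 2-fluorophenyl on an amine nitrogen gives an at least 3.5-fold lower number from compound 2 to compound 4 (0.55 log units; beyond the scatter), the first readable step. With the same group in place of 3-methylphenyl at this position, the result is an at least 3.5-fold lower number from compound 1 to compound 4 (0.55 log units; beyond the scatter), so this nitrogen does respond to change, and both steps start from limits and give only a minimum size. Compound 4 is the only compound shown with a number rather than a limit, and the rest of the series stays at that limit: the limit of > 20000 nM in this assay, at which 3 of the 4 values shown sit.

The compounds shown do not separate the contribution of the carbonyl from that of the methyl on the ring, and the full size of both steps remains unknown. A plain benzoyl or an acetyl group on the same nitrogen would help to separate the two.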